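A Chloro Substituent Added to a Weak Antiproliferative Lead

The compounds below may be only part of what the source reports. "The series", "measured", "known", "first", "only" and "open" are said of these compounds alone.

Compound 1 `O=C1COc2ccc(-c3cnc(Cl)c(NS(=O)(=O)c4ccc(F)cc4)c3)cc2N1c1ccccc1` was tested in a functional assay on HeLa cells (Homo sapiens) for antiproliferative activity, read by MTT assay, with a stated time of 72 h (on this read-out higher numbers stand for weaker inhibition and lower numbers for stronger inhibition), and gave 10300 nM. Compound 2 `COc1ncc(-c2ccc3c(c2)N(c2ccc(F)cc2)C(=O)CO3)cc1NS(=O)(=O)c1ccc(F)cc1` gave 10500 nM in this assay; these two numbers lie within the scatter of each other, so neither stands apart from the other. Compound 3 `O=C1COc2ccc(-c3cnc(Cl)c(NS(=O)(=O)c4ccc(F)cc4)c3)cc2N1c1ccc(Cl)cc1` has not yet been measured. It differs from compound 1 by chloro in place of hydrogen on an aromatic carbon. No measured step of this kind is available among these compounds, so the step expected in this assay is a 1.3-fold lower number from compound 1 to compound 3 (0.11 log units; within the scatter), not beyond the scatter. Compound 3 is therefore estimated at 8000 nM, within a range of 3000 nM to 25000 nM.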

Compound 3, half-maximal inhibitory concentration: > 40000 nM
Compound 3: only a limit was reported; the forecaster's own chance of this, stated with the estimate: 5%; middle value at least 5.0-fold (0.69 log units) away from the limit.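

Compound 3 gives > 40000 nM in this assay, which is a limit of the assay and not a number. The earlier compounds shown here offered no comparison of a change in one place, and here the change from phenyl to 4-chlorophenyl gives an at least 3.8-fold higher number from compound 1 to compound 3 (0.58 log units; beyond the scatter). This position is therefore not indifferent: a single added chlorine, para to a large group, is enough to weaken inhibition clearly. On these data alone, whether an amine or a carboxylic acid at the same place would also weaken inhibition remains open. As far as these compounds go, the full size of this step remains open too.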